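Shorter amine chain: expected step for compound 4

A few compounds are considered here, and "the series" means these few. Any claim that something is new, unique, unknown or untested is made for them only; others in the source may bear on it.

Within the data shown here, in a functional assay on PC-3 cells (Homo sapiens) for antiproliferative activity, read by MTT assay, with a stated time of 72 h (on this read-out lower numbers stand for stronger inhibition and higher numbers for weaker inhibition), compound 3 `CCCCCCCCCNC[C@@H]1OC[C@H](N)[C@H]1O` gives 7650 nM, the middle of the three numbers so far. Compound 2 `CCCCCCCCCCCCNC[C@@H]1OC[C@H](N)[C@H]1O` lies lower at 2380 nM, and compound 1 `CCCCCCCNC[C@@H]1OC[C@H](N)[C@@H]1O` lies higher at 22400 nM. The next case is compound 4 `CCCCCCCNC[C@@H]1OC[C@H](N)[C@H]1O`. Its change from compound 3 is hydrogen in place of ethyl on a saturated chain carbon, seven bonds along the chain from an amine nitrogen.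

Among the measured compounds shown here, one measured step bears directly on this change, the replacement of propyl by hydrogen on the same chain: a 3.2-fold higher number from compound 2 to compound 3 (0.51 log units; beyond the scatter). That step was modest and removed a larger group than ethyl. A single step establishes no trend, but a smaller move in the same direction is expected in this assay. The expected change is a 2.1-fold higher number from compound 3 to compound 4 (0.32 log units; beyond the scatter). For compound 4 the estimated value is 16000 nM, with an expected range of 8000 nM to 32000 nM.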

Compound 4, half-maximal inhibitory concentration: > 128000 nM
Compound 4 was reported as a limit; the forecaster's own chance of this, stated with the estimate: 5%; middle value at least 8.0-fold (0.90 log units) away from the limit.
By their numbers in this assay, from the lowest: compound 2; then compound 3; then compound 1. At a limit, above all of these: compound 4.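

Shortening the amine chain does not cost activity evenly at this position: in this assay, an at least 16-fold higher number from compound 3 to compound 4 (1.22 log units; beyond the scatter), a large step for the loss of ethyl, whereas the earlier loss of propyl gave only a modest one, a 3.2-fold higher number from compound 2 to compound 3 (0.51 log units; beyond the scatter). Across the whole change in chain length, an at least 53-fold higher number from compound 2 to compound 4 (1.73 log units; beyond the scatter), and compound 4 is known only as a limit: the limit of > 128000 nM in this assay, at which 1 of the 4 values shown sits. Configuration also matters with this chain, since an at least 5.7-fold higher number from compound 1 to compound 4 (0.75 log units; beyond the scatter), with no change in the chain itself: the fact that compounds 1 and 4 differ only in the configuration as drawn.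

Going by these compounds, the true size of every step to compound 4 remains open, as does the effect of the configuration of compound 1 when paired with the longer chains of compound 2 and compound 3. On these data alone, whether a chain longer than that of compound 2 would lower the number further also remains open.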